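The compounds below may be only part of what the source reports. "The series", "measured", "known", "first", "only" and "open" are said of these compounds alone.

Compound 1 `COc1cc(/C=C/C(=O)c2cccc(-n3cc(-c4ccc(Cl)cc4)[nH]c3=O)c2)cc(OC)c1OC`: 2140 nM
Compound 2 `COc1cc(/C=C/C(=O)c2cccc(-n3cc(-c4ccccc4)[nH]c3=O)c2)cc(OC)c1OC`: 1380 nM
Compound 3 `COc1ccc(-c2cn(-c3cccc(C(=O)/C=C/c4cc(OC)c(OC)c(OC)c4)c3)c(=O)[nH]2)cc1`: 1610 nM

All three were tested in a functional assay on 786-0 cells (Homo sapiens) for inhibition; a lower number here means a stronger inhibitor of growth, a higher number a weaker inhibitor of growth. On these numbers compound 3 stands second highest of three, separated from compound 2 by a 1.2-fold higher number from compound 2 to compound 3 (0.07 log units; within the scatter) and from compound 1 by a 1.3-fold lower number from compound 1 to compound 3 (0.12 log units; within the scatter), so no real order among them can be claimed. Compound 4 `COc1cc(/C=C/C(=O)c2cccc(-n3cc(-c4cc(OC)c(OC)c(OC)c4)[nH]c3=O)c2)cc(OC)c1OC` is not yet measured. It differs from compound 3 by 3,4,5-trimethoxyphenyl in place of 4-methoxyphenyl on an aromatic carbon. The measured steps that bear on this same place, a 1.3-fold lower number from compound 1 to compound 3 (0.12 log units; within the scatter) and a 1.2-fold higher number from compound 2 to compound 3 (0.07 log units; within the scatter), both lie within the scatter. A further change there is therefore expected to move this assay little, and compound 4 is estimated at 1500 nM, within 700 nM to 3500 nM, an expected step of a 1.1-fold lower number from compound 3 to compound 4 (0.03 log units; within the scatter) that should stay within the scatter.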

Compound 4, concentration for 50% growth inhibition: 1590 nM
Compound 4: the middle estimate sits 1.1-fold (0.03 log units) below what was measured; the measured number falls inside the stated range.
By their numbers in this assay, from the lowest: compounds 2, 4, 3 and 1 (each within the scatter of the next).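

Moving to the larger 3,4,5-trimethoxyphenyl group still gives no separation in this assay (a 1.0-fold lower number from compound 3 to compound 4 (0.01 log units; within the scatter)), and the same holds against the other two aryl groups (a 1.2-fold higher number from compound 2 to compound 4 (0.06 log units; within the scatter); a 1.3-fold lower number from compound 1 to compound 4 (0.13 log units; within the scatter)). The position thus carries a group with more heavy atoms and more hydrogen-bond acceptors than 4-methoxyphenyl without any step beyond the scatter, so no order can be claimed among the four compounds. Nothing available explains this flat result. On these data alone, whether a non-aryl group here, such as an amine, a carboxylic acid or a longer alkyl chain, would move this number remains open.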